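Ring swap on the sulfonyl sulfur and Vero cell tolerance

The source may hold more compounds than are shown below. What is called first, only, known or untested is meant among the compounds shown, and "the series" means these compounds.

Compound 1 `Cn1nc(C(F)(F)F)cc1C(=O)Nc1ccc(S(=O)(=O)N2CCCCCCC2)cc1` is the anchor of this pair. Within the data shown here, in an ADME assay on Vero cells (Chlorocebus sabaeus) for cytotoxicity, read by MTT assay (on this read-out higher numbers stand for lower toxicity in this test and lower numbers for higher toxicity in this test), compound 1 gives 16000 nM, the lowest of the two numbers so far. Compound 2 `Cn1nc(C(F)(F)F)cc1C(=O)Nc1ccc(S(=O)(=O)N2CCNCC2)cc1` gives 126000 nM in this assay, and the step of a 7.9-fold higher number from compound 1 to compound 2 (0.90 log units; beyond the scatter) shows that exchanging the eight-membered ring for a six-membered ring with two hetero atoms already moved the number well beyond the scatter.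

Compound 3 `Cn1nc(C(F)(F)F)cc1C(=O)Nc1ccc(S(=O)(=O)N2CCC(N)CC2)cc1` has not yet been measured in this assay. Relative to compound 1 it carries a group of 7 heavy atoms (5 carbon, 2 nitrogen; one six-membered non-aromatic ring with 1 hetero atom) in place of a group of 8 heavy atoms (7 carbon, 1 nitrogen; one eight-membered non-aromatic ring with 1 hetero atom), on a sulfonyl sulfur. Among the measured compounds shown here, the only measured step that bears on this change is the one from compound 1 to compound 2, which likewise replaced the eight-membered ring with a smaller ring bearing a second nitrogen. Compound 3 is therefore expected to show a step of a 6.3-fold higher number from compound 1 to compound 3 (0.80 log units; beyond the scatter), in the same direction. Compound 3 is estimated at 100000 nM, with a range from 30000 nM to 300000 nM.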

Compound 3, half-maximal cytotoxic concentration: > 300000 nM
Compound 3 gave a limit, no number; the forecaster's own chance of this, stated with the estimate: 25%; middle value at least 3.0-fold (0.47 log units) from the limit.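

The value of compound 3 in this assay is a limit and not a number: the limit of > 300000 nM in this assay, at which 1 of the 3 values shown sits. On the sulfonyl sulfur, 4-aminopiperidin-1-yl in place of the eight-membered ring gives an at least 18-fold higher number from compound 1 to compound 3 (1.27 log units; beyond the scatter), so this position allows a larger move towards lower toxicity in this test than compound 2 had shown. The two six-membered rings are also not interchangeable here, as 4-aminopiperidin-1-yl in place of piperazin-1-yl gives an at least 2.3-fold higher number from compound 2 to compound 3 (0.37 log units; beyond the scatter), a step beyond the scatter.

As far as these compounds go, it remains open what a piperidin-1-yl ring without the amine, or one carrying a hydroxyl group at that place, would give in this assay, so the part played by the amine cannot be separated from that of the ring. From the compounds shown here alone, how far compound 3 lies past its limit also stays open, and both new steps therefore give only their smallest possible size.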